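This account rests on a few compounds, and the source may have more. Where it says the series, first, only, none or still open, it means among the compounds named here.

Measured compounds in an assay (brain) for inhibition of Fatty-acid amide hydrolase 1 (Mus musculus), with stated times of 20 min and 15 min; a lower number here means a stronger inhibitor, a higher number a weaker inhibitor:
compound 1 `NC(=O)c1ccn(-c2cccc(OC(=O)NCCCCCCc3ccccc3)c2)c1` gives 0.16 nM
compound 2 `CCCCNC(=O)Oc1cccc(-c2oc(C)cc2C(N)=O)c1` gives 140 nM
compound 3 `Cc1cc(C(N)=O)c(-c2cccc(OC(=O)NCCCCCCc3ccccc3)c2)o1` gives 0.49 nM

Compound 3 stands second highest of these three numbers in this assay. Its nearest neighbour is compound 1, and the step from that compound to compound 3 is a 3.1-fold higher number from compound 1 to compound 3 (0.49 log units; beyond the scatter). Its furthest neighbour is compound 2, where the step is a 290-fold lower number from compound 2 to compound 3 (2.46 log units; beyond the scatter), so compound 3 sits far from the weak end and close to the strong end.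

Compound 4 `Cc1oc(-c2cccc(OC(=O)NCCCCCCc3ccccc3)c2)cc1C(N)=O` is not yet measured. The change from compound 3 to compound 4 is 4-carbamoyl-5-methylfuran-2-yl in place of 3-carbamoyl-5-methylfuran-2-yl on an aromatic carbon. The same atoms are present in both, only joined differently: the carboxamide has moved to another position on the furan ring while the methyl stays. Within the data shown here, no measured step covers exactly this rearrangement. The step that bears on it most is the swap of the heteroaryl group, which gave a 3.1-fold higher number from compound 1 to compound 3 (0.49 log units; beyond the scatter), a modest shift. The large step of a 290-fold lower number from compound 2 to compound 3 (2.46 log units; beyond the scatter) concerns the chain and not the heteroaryl, so it says little here. Only a modest step is therefore expected in this assay, in either direction. Compound 4 is estimated at 1 nM, within the range 0.2 nM to 5 nM, which corresponds to an expected step of a 2.0-fold higher number from compound 3 to compound 4 (0.31 log units; beyond the scatter).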

Compound 4, inhibition constant: 4.8 nM
Compound 4: the middle estimate sits 4.8-fold (0.68 log units) below what was measured; the range from low to high includes it.
By their numbers in this assay, from the lowest: compound 1; then compound 3; then compound 4; then compound 2.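

In this assay, putting 4-carbamoyl-5-methylfuran-2-yl in place of 3-carbamoyl-5-methylfuran-2-yl keeps the same atoms and the same counted features, yet gives a 9.8-fold higher number from compound 3 to compound 4 (0.99 log units; beyond the scatter) in a single change on the shared core. Among these compounds, this position therefore responds to how the furan and its groups are joined, and not only to which atoms are present, something the earlier compounds could not show because none of them kept the atoms fixed. This rearrangement also moves the number further than the earlier heteroaryl swap, a 3.1-fold higher number from compound 1 to compound 3 (0.49 log units; beyond the scatter), and the pyrrole compound now stands well apart from the new furan, with a 30-fold higher number from compound 1 to compound 4 (1.48 log units; beyond the scatter), while no measurement here explains any of these differences.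

The compounds shown leave open whether the carboxamide itself matters at this position, since neither a carboxylic acid nor a nitrile appears in its place on either furan. They also leave open what the methyl contributes, as no furan without it is shown, and whether the shorter butyl chain of compound 2 would respond in the same way to this rearrangement.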